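Compound 4 against compounds 1 to 3: working notes

A few compounds are considered here, and "the series" means these few. Any claim that something is new, unique, unknown or untested is made for them only; others in the source may bear on it.

Measured in an assay on CHO cells for displacement of a labelled ligand from 5-hydroxytryptamine receptor 7 (Homo sapiens); a lower number here means a stronger inhibitor, a higher number a weaker inhibitor:
compound 1 `CCC1(CCCCN2CCN(c3cccc(Cl)c3)CC2)C(=O)Nc2cc(F)ccc21` gives 0.67 nM
compound 2 `CCC1(CCCCN2CCN(c3cccc(Cl)c3)CC2)C(=O)Nc2cc(F)c(Cl)cc21` gives 9.07 nM
compound 3 `CCC1(CCCCN2CCN(c3ccc(OC)cc3)CC2)C(=O)Nc2ccccc21` gives 25.4 nM

Compound 3 stands highest of the three numbers, with compound 2 nearest and compound 1 furthest. Compound 4 `CCC1(CCCCN2CCN(c3ccccc3OC)CC2)C(=O)Nc2ccccc21` keeps the same atoms as compound 3, joined differently: 2-methoxyphenyl in place of 4-methoxyphenyl on an amine nitrogen in a ring. Among the measured compounds shown here, the only measured step, a 14-fold higher number from compound 1 to compound 2 (1.13 log units; beyond the scatter), concerns a chloro on an aromatic carbon of the shared core and does not touch the methoxyphenyl; no measured pair varies the group on the amine nitrogen in the ring. For the measured compounds named here, there is thus no measured step to set direction or size, and the step of a 1.0-fold lower number from compound 3 to compound 4 (0.01 log units; within the scatter) expected for compound 4 is none beyond the scatter. Compound 4 is estimated at 25 nM, range 8 nM to 80 nM.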

Compound 4, inhibition constant: 5.38 nM
Beside the measured number, compound 4's estimate is 4.6-fold (0.67 log units) above it; measured number outside the range, below it.
By their numbers in this assay, from the lowest: compound 1; then compounds 4 and 2 (each within the scatter of the next); then compound 3.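

In this assay, this position on an amine nitrogen in a ring responds to how the same atoms are joined: 2-methoxyphenyl in place of 4-methoxyphenyl gives a 4.7-fold lower number from compound 3 to compound 4 (0.67 log units; beyond the scatter) with no change in the counted atoms, donors or acceptors. Among the compounds shown here, until now, the only measured step concerned a chloro on the shared core. Nothing shown accounts for this step.

Going by these compounds, it remains open whether 2-methoxyphenyl has the same effect on the fluoro-bearing core of compound 1. Also open, on these data alone, is what a 2-ethoxyphenyl or 2-hydroxyphenyl group would give here.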